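Aryl substituent on the sulfur-bound phenyl of the series

The source may report more compounds than this note shows. Statements on the series, on what has been measured and on what is new or still open speak of the compounds shown alone.

Among the measured compounds shown here, compound 3 `OC[C@H]1O[C@@H](n2cnc3c(CSc4cccc(Br)c4)ncnc32)[C@H](O)[C@@H]1O` gives 363 nM in an assay on isolated protein for binding affinity to Equilibrative nucleoside transporter 1 (Homo sapiens) (on this read-out lower numbers stand for stronger inhibition and higher numbers for weaker inhibition), and stands lowest of the three numbers measured so far. Compound 1 `CCSc1ncnc2c1ncn2[C@@H]1O[C@H](CO)[C@@H](O)[C@H]1O` gives 57500 nM and compound 2 `Cc1cccc(CSc2ncnc3c2ncn3[C@@H]2O[C@H](CO)[C@@H](O)[C@H]2O)c1` gives 12000 nM; the steps are a 160-fold lower number from compound 1 to compound 3 (2.20 log units; beyond the scatter) and a 33-fold lower number from compound 2 to compound 3 (1.52 log units; beyond the scatter), so compound 3 is clearly the strongest of the three.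

Compound 4 `CC(C)(C)c1ccc(SCc2ncnc3c2ncn3[C@@H]2O[C@H](CO)[C@@H](O)[C@H]2O)cc1` differs from compound 3 in one place: 4-(tert-butyl)phenyl in place of 3-bromophenyl on a sulfur. For the measured compounds named here, no measured step changes the substituent on an aryl group bound to the sulfur; the only step that swaps one aryl for another, a 33-fold lower number from compound 2 to compound 3 (1.52 log units; beyond the scatter), also moves the sulfur and the saturated chain carbon and so does not bear directly on it. The step of a 4.8-fold lower number from compound 1 to compound 2 (0.68 log units; beyond the scatter) adds an aryl group where none was, which is likewise a different kind of change.

Going by the values given here, with no direct precedent, compound 4 is expected to stay near compound 3, and a step of a 2.2-fold higher number from compound 3 to compound 4 (0.34 log units; beyond the scatter) is estimated, with wide uncertainty. The estimate for compound 4 in this assay is 800 nM, between 150 nM and 4000 nM.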

Compound 4, half-maximal inhibitory concentration: 331000 nM
Compound 4: the middle estimate sits 410-fold (2.62 log units) below what was measured; measured number outside the range, above it.
By their numbers in this assay, from the lowest: compound 3; then compound 2; then compound 1; then compound 4.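

The aryl group on this sulfur proved highly sensitive to substitution: 4-(tert-butyl)phenyl in place of 3-bromophenyl gives a 910-fold higher number from compound 3 to compound 4 (2.96 log units; beyond the scatter) in this assay, with the rest of the structure unchanged. An aryl group on this sulfur therefore does not by itself secure a low number, and the substituents on that aryl group can move the result by a large margin, up to the highest number of the four compounds. No available evidence explains the size of this step.

The step swaps both the group and its printed ring position, so the compounds shown do not separate the contribution of bromine leaving from that of tert-butyl entering, and 4-bromophenyl and 3-(tert-butyl)phenyl would address this directly. On these data alone, how an amine or a carboxylic acid on this phenyl would read out also remains open.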